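Propanamide to Methyl Carbamate: Expected Solubility

This account rests on a few compounds, and the source may have more. Where it says the series, first, only, none or still open, it means among the compounds named here.

Within the data shown here, compound 2 `CCC(=O)NC[C@H]1CN(c2ccc(-n3cc(-c4ccccn4)cn3)c(F)c2)C(=O)O1` stands at the lower end of the two solubility numbers known so far: in a physicochemical assay for solubility, read by HPLC, with a stated time of 24 h (on this read-out higher numbers stand for higher solubility and lower numbers for lower solubility), compound 2 gives 147000 nM. Compound 1 `CCN1CCN(C[C@H]2CN(c3ccc(-n4cc(-c5ccccn5)cn4)c(F)c3)C(=O)O2)CC1` gives 706000 nM in this assay, and the step of a 4.8-fold lower number from compound 1 to compound 2 (0.68 log units; beyond the scatter) separates the two. Compound 3 `COC(=O)NC[C@H]1CN(c2ccc(-n3cc(-c4ccccn4)cn3)c(F)c2)C(=O)O1` differs from compound 2 only by methoxy in place of ethyl on a carbonyl carbon. Among the measured compounds shown here, no measured step swaps these two groups, and the single known step concerns an unrelated replacement, so it gives no direct guide. A shift within the scatter is therefore expected. Compound 3 is estimated at 150000 nM, between 60000 nM and 350000 nM, an expected 1.0-fold higher number from compound 2 to compound 3 (0.01 log units; within the scatter).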

Compound 3, solubility: 34100 nM
The estimate for compound 3 lay 4.4-fold (0.64 log units) above the measured number; measured number below the stated range.
By their numbers in this assay, from the lowest: compound 3; then compound 2; then compound 1.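

At this carbonyl carbon the swap matters: in this assay methoxy in place of ethyl gives a clear drop (a 4.3-fold lower number from compound 2 to compound 3 (0.63 log units; beyond the scatter)), though both groups count the same number of heavy atoms. Replacing 4-ethylpiperazin-1-yl with (methoxycarbonyl)amino gives a larger step (a 21-fold lower number from compound 1 to compound 3 (1.32 log units; beyond the scatter)), leaving compound 3 the lowest of the three. Nothing available here explains the drop.

Going by these compounds, whether other groups on this carbonyl carbon, such as ethoxy or a dimethylamino group, would fall nearer compound 2 or compound 3 stays open. So does whether the methoxy step would carry over to a different core.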